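This account rests on a few compounds, and the source may have more. Where it says the series, first, only, none or still open, it means among the compounds named here.

Measured so far in a functional assay on MCF7 cells (Homo sapiens) for cytotoxicity, read by sulforhodamine B assay, with a stated time of 48 h; on this read-out lower numbers stand for stronger inhibition and higher numbers for weaker inhibition:

- compound 1 `N#Cc1c(-c2ccc(Cl)cc2)cc(-c2ccc(Cl)cc2)n([C@@H]2O[C@H](CO)[C@@H](O)[C@H](O)[C@H]2O)c1=O`: 14.2 ug/mL
- compound 2 `C=CCn1c(-c2ccc(Cl)cc2)cc(-c2ccc(Cl)cc2)c(C#N)c1=O`: 19 ug/mL

Only these two compounds have been measured, so compound 2, at 19 ug/mL, has just one neighbour, compound 1. The two values lie within the scatter of each other, and no ranking can be drawn between them.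

The next compound is compound 3 `C#CCn1c(-c2ccc(Cl)cc2)cc(-c2ccc(Cl)cc2)c(C#N)c1=O`. It carries ethynyl in place of vinyl on a saturated chain carbon bound to an aromatic nitrogen, which can also be read as allyl to propargyl.

Going by the values given here, no measured step makes this exchange. The only one that bears on it is a 1.3-fold higher number from compound 1 to compound 2 (0.13 log units; within the scatter), which put allyl in place of 3,4,5-trihydroxy-6-(hydroxymethyl)oxan-2-yl on an aromatic nitrogen. That replacement at the same nitrogen stayed within the scatter, so one step is the whole evidence that this assay tolerates change there. Nothing in the data indicates a direction, and no shift beyond the scatter is expected.

The expected change is a 1.1-fold lower number from compound 2 to compound 3 (0.05 log units; within the scatter), an estimate that stays within the scatter. For compound 3 the estimated value is 17 ug/mL, with an expected range from 8 ug/mL to 35 ug/mL.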

Compound 3, half-maximal inhibitory concentration: 16.7 ug/mL
Estimate against measurement, compound 3: 1.0-fold (0.01 log units) above; the measured number falls inside the stated range.
By their numbers in this assay, from the lowest: compounds 1, 3 and 2 (each within the scatter of the next).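

In this assay, ethynyl in place of vinyl on a saturated chain carbon bound to an aromatic nitrogen gives a 1.1-fold lower number from compound 2 to compound 3 (0.06 log units; within the scatter) and so leaves the double bond and the triple bond indistinguishable on this read-out. Propargyl in place of 3,4,5-trihydroxy-6-(hydroxymethyl)oxan-2-yl on the same nitrogen gives a 1.2-fold higher number from compound 1 to compound 3 (0.07 log units; within the scatter) and thus adds a second small unsaturated chain to the allyl step, so the tolerance for change at this nitrogen now rests on two steps rather than one. Nothing available explains why the three values lie so close together.

The compounds shown leave open whether any group at this nitrogen would carry the number beyond the scatter, such as a longer chain, a chain ending in an amine or a carboxylic acid, or a plain hydrogen. From the compounds shown here alone, the nitrile and both 4-chlorophenyl groups are the same in all three compounds, so what a change there would do, for example a methoxy group in place of the chlorine, also remains unknown.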